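Same Ring Swap, Second Core, One Compound Still Unmeasured

The source may hold more compounds than are shown below. What is called first, only, known or untested is meant among the compounds shown, and "the series" means these compounds.

Three compounds were tested in a functional assay on HeLa cells (Homo sapiens) for inhibition, read by MTT assay, with a stated time of 72 h; a higher number here means a weaker inhibitor, a lower number a stronger inhibitor. Compound 1 `CN(C(=O)NC(=O)c1ccc(Cl)cc1Cl)c1nc(C(F)(F)F)c(C(=O)N/N=C/c2cccc(C(F)(F)F)c2)s1` gave 9.6 ug/mL in this assay, and compound 3 `CN(C(=O)NC(=O)c1ccc(Cl)cc1Cl)c1nc(C(F)(F)F)c(C(=O)N/N=C/c2ccccc2C(F)(F)F)s1` gave 9 ug/mL. Compound 2 `Cc1nc(N(C)C(=O)NC(=O)c2c(F)cccc2F)sc1C(=O)N/N=C/c1cccc(C(F)(F)F)c1`, built on a different core, gave 26.8 ug/mL in this assay; how its core differs from the core of compound 1 is not broken down here. Compound 2 has the highest number of the three, and its gaps to compound 1 and to compound 3 both lie beyond the usual scatter of repeated measurements.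

Compound 1 and compound 3 differ in one place only: 2-(trifluoromethyl)phenyl in place of 3-(trifluoromethyl)phenyl on a carbon with a double bond to nitrogen. This change produced a 1.1-fold lower number from compound 1 to compound 3 (0.03 log units; within the scatter), a step that lies within the scatter, so the two numbers are read as alike.

Compound 4 `Cc1nc(N(C)C(=O)NC(=O)c2c(F)cccc2F)sc1C(=O)N/N=C/c1ccccc1C(F)(F)F` has not yet been measured in this assay. It stands to compound 2 as compound 3 stands to compound 1, the same change at the same place: 2-(trifluoromethyl)phenyl in place of 3-(trifluoromethyl)phenyl on a carbon with a double bond to nitrogen. Within the data shown here, the only guide is the one measured example, where the change gave a 1.1-fold lower number from compound 1 to compound 3 (0.03 log units; within the scatter), so a similarly small movement is anticipated, with a wider band of uncertainty because the core of compound 2 has only the value 26.8 ug/mL to anchor it. Compound 4 is expected to show a step of a 1.1-fold lower number from compound 2 to compound 4 (0.03 log units; within the scatter). In this assay compound 4 is estimated at 25 ug/mL, with a likely range from 12 ug/mL to 50 ug/mL.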

Compound 4, half-maximal inhibitory concentration: 6.51 ug/mL
Estimate against measurement, compound 4: 3.8-fold (0.58 log units) above; the whole stated range lies above it.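

On the core of compound 2, 2-(trifluoromethyl)phenyl in place of 3-(trifluoromethyl)phenyl gave a 4.1-fold lower number from compound 2 to compound 4 (0.61 log units; beyond the scatter) in this assay. The size of this step therefore did not carry over from one core to the other, as the two steps set side by side show: the same change on two cores in this assay, a 1.1-fold lower number (0.03 log units; within the scatter) from compound 1 to compound 3 and a 4.1-fold lower number (0.61 log units; beyond the scatter) from compound 2 to compound 4, 3.9-fold (0.59 log units) apart, beyond the scatter of two such steps. This does not show which part of the core sets the size of the step, as compound 1 and compound 2 differ in more than one place, and two cores give no rule for predicting the step on a third.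

The compounds shown leave open whether the step depends on the methyl group of compound 2, its difluorophenyl group, or both, a question that a core pairing that methyl group with the dichlorophenyl group of compound 1 could help to separate. They also leave open how either core responds when the trifluoromethyl group on the phenyl ring is replaced by a nitrile, a methoxy group or a carboxylic acid, and whether the larger step on the core of compound 2 would appear with those groups as well.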